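Halogen swap on a catechol chromone amine: cytotoxicity outlook

The compounds below may be only part of what the source reports. "The series", "measured", "known", "first", "only" and "open" are said of these compounds alone.

Three close relatives of one shared core have been examined in an ADME assay on Huh-7 cells (Homo sapiens) for cytotoxicity; on this read-out lower numbers stand for higher toxicity in this test and higher numbers for lower toxicity in this test. Compound 1 `O=c1cc(CNCc2cccc(F)c2)oc2ccc(O)c(O)c12` carries a 3-fluorophenyl group on the saturated chain carbon bound to the amine nitrogen. In this assay compound 1 gives only a limit, > 100000 nM. Compound 2 `O=c1cc(CNCc2cccc(Cl)c2)oc2ccc(O)c(O)c12` differs from compound 1 by chloro in place of fluoro on an aromatic carbon. For compound 2 this assay also reports a limit, > 100000 nM. Compound 3 `O=c1cc(CNCc2ccc(F)cc2)oc2ccc(O)c(O)c12` is built from the same atoms as compound 1, joined differently: 4-fluorophenyl in place of 3-fluorophenyl on a saturated chain carbon bound to an amine nitrogen. Compound 3 too stands at a limit, > 100000 nM.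

Among the measured compounds shown here, the step that the two limits leave unreadable from compound 1 to compound 2 therefore cannot be sized, and the same holds for the other two pairs, since the limit of > 100000 nM in this assay, at which 3 of the 3 values shown sit, covers every value so far.

Compound 4 `O=c1cc(CNCc2ccc(Cl)cc2)oc2ccc(O)c(O)c12` has not yet been tested. It differs from compound 3 by chloro in place of fluoro on an aromatic carbon. This is the same kind of change as from compound 1 to compound 2, but the place is not identical: in compound 4 the chloro sits para to a large group, whereas in compound 2 it sits meta to a large group. Because all three measured relatives sit at the limit of > 100000 nM in this assay, at which 3 of the 3 values shown sit, compound 4 is expected to remain at that limit as well, with an estimated step that the limit leaves unreadable from compound 3 to compound 4. The estimated value for compound 4 in this assay is 150000 nM, with an expected range from 100000 nM to 300000 nM.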

Compound 4, half-maximal cytotoxic concentration: > 100000 nM
Compound 4 was reported as a limit (the forecaster's own chance of this, stated with the estimate: 85%); the middle value lies beyond the limit too.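

In this assay compound 4 also stands at a limit, > 100000 nM. Its steps from compound 1, compound 2 and compound 3 therefore cannot be read, and none of them can be sized: the limit of > 100000 nM in this assay, at which 4 of the 4 values shown sit.

The compounds shown leave open how far any of the four lies beyond that limit, and so whether chloro in place of fluoro changes the read-out in this assay at all.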